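This account rests on a few compounds, and the source may have more. Where it says the series, first, only, none or still open, it means among the compounds named here.

Among the measured compounds shown here, in a functional assay on HepG2 cells (Homo sapiens) for antiproliferative activity, read by spectrophotometry, with a stated time of 2 days (on this read-out higher numbers stand for weaker inhibition of growth and lower numbers for stronger inhibition of growth), compound 2 `COc1cc(Nc2ncc(C(F)(F)F)c(N3Cc4cccc(N(C)S(C)(=O)=O)c4C3)n2)cc(OC)c1` gives 1800 nM, the only true number so far. Compound 1 `COc1ccc(C(F)(F)F)cc1Nc1ncc(C(F)(F)F)c(N2Cc3cccc(N(C)S(C)(=O)=O)c3C2)n1` gives > 30000 nM, which is a limit of the assay. Compound 3 `Cc1cc(C)cc(Nc2ncc(C(F)(F)F)c(N3Cc4cccc(N(C)S(C)(=O)=O)c4C3)n2)c1` carries 3,5-dimethylphenyl in place of 3,5-dimethoxyphenyl on a nitrogen on an aromatic ring. For the measured compounds named here, the one measured step, an at least 16-fold lower number from compound 1 to compound 2 (1.22 log units; beyond the scatter), is large but swaps in a different group, so it gives no direction for this change, and no step beyond the scatter is expected in this assay. The expected step is a 1.1-fold higher number from compound 2 to compound 3 (0.05 log units; within the scatter). Compound 3 is estimated at 2000 nM, with an expected range of 600 nM to 8000 nM.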

Compound 3, concentration for 50% growth inhibition: > 30000 nM
Compound 3 was reported as a limit (the forecaster's own chance of this, stated with the estimate: 10%); middle value at least 15-fold (1.17 log units) away from the limit.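

In this assay, the exchange on this nitrogen proves far from neutral: 3,5-dimethylphenyl in place of 3,5-dimethoxyphenyl gives an at least 16-fold higher number from compound 2 to compound 3 (1.22 log units; beyond the scatter). The 3,5-dimethylphenyl group does not retain the activity of the 3,5-dimethoxyphenyl group, so among these compounds the methoxy groups go with the only true number. The step's real size stays unknown, and the step between compound 1 and compound 3 cannot be read, since both values are limits: the limit of > 30000 nM in this assay, at which 2 of the 3 values shown sit.

On these data alone, it remains open whether a single methoxy group, an ethoxy group, a hydroxyl or an amine on this phenyl ring would keep the activity.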